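Hydroxy for Fluoro on a Weakly Cytotoxic Hydrazone

This account rests on a few compounds, and the source may have more. Where it says the series, first, only, none or still open, it means among the compounds named here.

Of the compounds shown here, three sharing one core have been tested in a functional assay on A549 cells (Homo sapiens) for cytotoxicity, read by XTT assay, with a stated time of 24 h; a lower number here means a stronger inhibitor, a higher number a weaker inhibitor. Compound 1 `Cn1nnnc1SCC(=O)N/N=C/c1ccc(Br)cc1` reaches only the limit of the assay, > 10000000 nM. Compound 2 `Cn1nnnc1SCC(=O)N/N=C/c1cccc([N+](=O)[O-])c1` likewise gives the limit > 10000000 nM. For the measured compounds named here, compound 3 `Cn1nnnc1SCC(=O)N/N=C/c1cccc(F)c1` is the only one with an actual number, 6320000 nM. Going by the values given here, the one measured step is an at least 1.5-fold lower number from compound 2 to compound 3 (0.19 log units; that floor lies within the scatter), and it lies within the scatter since two of the three values sit at the limit of > 10000000 nM in this assay, at which 2 of the 3 values shown sit. Compound 4 `Cn1nnnc1SCC(=O)N/N=C/c1cccc(O)c1` is not yet measured; it differs from compound 3 by hydroxy in place of fluoro on an aromatic carbon. Among the compounds with values here, no measured step swaps fluoro for hydroxy, so no change beyond the scatter is expected, with a real chance that compound 4 again returns only the limit. Compound 4 is therefore expected at 8000000 nM, between 3000000 nM and 20000000 nM. That estimate means a step of a 1.3-fold higher number from compound 3 to compound 4 (0.10 log units; within the scatter).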

Compound 4, half-maximal inhibitory concentration: 4500000 nM
For compound 4 the middle estimate is 1.8-fold (0.25 log units) above the measured one; measured number inside the range.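

Hydroxy in place of fluoro gives a 1.4-fold lower number from compound 3 to compound 4 (0.15 log units; within the scatter), so on this aromatic carbon the swap to a group with a hydrogen-bond donor and acceptor brings no change that can be read. Hydroxy in place of nitro gives an at least 2.2-fold lower number from compound 2 to compound 4 (0.34 log units; beyond the scatter), the first step at this position to pass beyond the scatter. That step is only a floor, since its starting value for compound 2 is a limit and not a number: the limit of > 10000000 nM in this assay, at which 2 of the 4 values shown sit.

From the compounds shown here alone, what an amine or a carboxylic acid on the same carbon would do remains open. So does whether a methoxy group would behave like hydroxy.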